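Thiophen-2-yl Gives Way to Phenyl

The source may report more compounds than this note shows. Statements on the series, on what has been measured and on what is new or still open speak of the compounds shown alone.

In a functional assay on DU-145 cells (Homo sapiens) for inhibition, read by MTT assay, with a stated time of 48 h (a higher number here means a weaker inhibitor, a lower number a stronger inhibitor), compound 1 `c1ccc(Sc2c(-c3cccs3)nc3ccccn23)cc1` gives 24100 nM. Compound 2 `Clc1ccc(Sc2c(-c3cccs3)nc3ccccn23)cc1` gives 92300 nM, the higher of the two numbers, which makes it the weaker inhibitor of this pair. Among the compounds with values here, the one measured step, a 3.8-fold higher number from compound 1 to compound 2 (0.58 log units; beyond the scatter), is modest and comes from chloro in place of hydrogen on an aromatic carbon.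

Compound 3 `Clc1ccc(Sc2c(-c3ccccc3)nc3ccccn23)cc1` keeps the chloro group of compound 2 but has phenyl in place of thiophen-2-yl on an aromatic carbon. Within the data shown here, no measured step tests this swap. The chloro step is a different change, so it shows only how far one swap has moved the numbers here and gives no direction. No step beyond the scatter is therefore expected in this assay, and the estimated step is a 1.4-fold lower number from compound 2 to compound 3 (0.15 log units; within the scatter). For compound 3 the expected value is 65000 nM, with an estimated range of 22000 nM to 180000 nM.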

Compound 3, half-maximal inhibitory concentration: 76700 nM
For compound 3 the middle estimate is 1.2-fold (0.07 log units) below the measured one, within the range that was stated.
By their numbers in this assay, from the lowest: compound 1; then compounds 3 and 2 (each within the scatter of the next).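

Replacing thiophen-2-yl with phenyl, on an aromatic carbon next to the ring nitrogen, barely registers in this assay: the swap gives a 1.2-fold lower number from compound 2 to compound 3 (0.08 log units; within the scatter), so with the chloro group present the two rings cannot be told apart at this position. The sulfur of the five-membered ring leaves and a six-membered ring of carbon only enters, yet in this single pair the number stays within the scatter, unlike the chloro change, which gave a 3.8-fold higher number from compound 1 to compound 2 (0.58 log units; beyond the scatter). Nothing measured here offers an explanation for either result.

As far as these compounds go, whether phenyl and thiophen-2-yl would also match in the core of compound 1, with hydrogen in place of chloro, remains open. So does whether a ring-free group at this position, such as an amine or a longer chain, would move the number beyond the scatter.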